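Methyl on the Ring Oxygen and Cell Toxicity

The compounds below may be only part of what the source reports. "The series", "measured", "known", "first", "only" and "open" are said of these compounds alone.

Compound 1 `Cn1nnnc1SCC(=O)N/N=C/c1ccc(O)cc1`: in an ADME assay on NIH3T3 cells (Mus musculus) for cytotoxicity, read by XTT assay, with a stated time of 24 h (on this read-out higher numbers stand for weaker inhibition and lower numbers for stronger inhibition), compound 1 gives 632000 nM.
Compound 3 `Cn1nnnc1SCC(=O)N/N=C/c1cccc(O)c1`: in this assay compound 3 gives 3160000 nM.
Compound 2 `COc1ccc(/C=N/NC(=O)CSc2nnnn2C)cc1`: for compound 2 this assay reports only a limit, > 10000000 nM.

Compound 2 is compound 1 with methyl in place of hydrogen on an oxygen on an aromatic ring. That change made an at least 15-fold higher number from compound 1 to compound 2 (1.19 log units; beyond the scatter); its true size is not known because of the limit of > 10000000 nM in this assay, at which 1 of the 3 values shown sits. Compound 3 has the same atoms as compound 1, joined differently; the difference between the two cores is not broken down here. In this assay compound 3 shows a higher number than compound 1.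

Compound 4 `COc1cccc(/C=N/NC(=O)CSc2nnnn2C)c1` is compound 3 with methyl in place of hydrogen on an oxygen on an aromatic ring, the same change at the same place. Because the earlier change gave an at least 15-fold higher number from compound 1 to compound 2 (1.19 log units; beyond the scatter), compound 4 is expected to shift by a 9.5-fold higher number from compound 3 to compound 4 (0.98 log units; beyond the scatter). Compound 4 is thus estimated at 30000000 nM, and since that would pass (the limit of > 10000000 nM in this assay, at which 1 of the 3 values shown sits), a limit rather than a number is the likely outcome.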

Compound 4, half-maximal inhibitory concentration: 600000 nM
Estimate against measurement, compound 4: 50-fold (1.70 log units) above, outside the stated range (below it).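

Methyl in place of hydrogen on an oxygen on an aromatic ring gave a 5.3-fold lower number from compound 3 to compound 4 (0.72 log units; beyond the scatter) in this assay, so hydroxy to methoxy did not act here as it did on the core of compound 1. The two steps run in opposite directions, and the gap between them is real: the same change on two cores in this assay, an at least 15-fold higher number (1.19 log units; beyond the scatter) from compound 1 to compound 2 and a 5.3-fold lower number (0.72 log units; beyond the scatter) from compound 3 to compound 4, at least 83-fold (1.92 log units) apart, beyond the scatter of two such steps. This shows that the effect of the change did not carry from one core to the other, but it does not show why, and the size of the earlier step remains unknown as it rests on a limit: the limit of > 10000000 nM in this assay, at which 1 of the 4 values shown sits.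

The compounds shown carry only hydroxy or methoxy on the ring. As far as these compounds go, it remains open how a longer chain on the oxygen, such as ethoxy, or an amine in place of hydroxy would behave on either core.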